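Amide variations on the shared core: furan-2-yl replacing difluorophenyl

A few compounds are considered here, and "the series" means these few. Any claim that something is new, unique, unknown or untested is made for them only; others in the source may bear on it.

Measured so far:
compound 1 `O=C(CCCc1ccccc1)Nc1ccc(N2CCN(c3ccc(OC[C@@H]4CO[C@@](Cn5cncn5)(c5ccc(Cl)cc5Cl)O4)cc3)CC2)cc1` — 3780 nM
compound 2 `O=C(Nc1ccc(N2CCN(c3ccc(OC[C@@H]4CO[C@@](Cn5cncn5)(c5ccc(Cl)cc5Cl)O4)cc3)CC2)cc1)c1ccc(F)c(F)c1` — 8690 nM

In a functional assay on A549 cells (Homo sapiens) for inhibition, read by MTT assay, with a stated time of 48 h (a lower number here means a stronger inhibitor, a higher number a weaker inhibitor), compound 2 gives 8690 nM, the highest of the two numbers; its nearest neighbour is compound 1, which gives 3780 nM. For the measured compounds named here, the only step in hand, a 2.3-fold higher number from compound 1 to compound 2 (0.36 log units; beyond the scatter), shows that exchanging the group on the carbonyl carbon shifts this assay by a modest amount, beyond the scatter.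

Compound 3 `O=C(Nc1ccc(N2CCN(c3ccc(OC[C@@H]4CO[C@@](Cn5cncn5)(c5ccc(Cl)cc5Cl)O4)cc3)CC2)cc1)c1ccco1` differs from compound 2 only there: furan-2-yl in place of 3,4-difluorophenyl on a carbonyl carbon. Going by the values given here, no measured step covers a furan-2-yl group, so the one step above serves only as a gauge of how much this position has moved so far. On that basis a step of similar size or smaller, in either direction, is expected in this assay; a return toward compound 1 is not ruled out.

For compound 3 the estimate in this assay is 7000 nM, range 3000 nM to 16000 nM, implying an expected step of a 1.2-fold lower number from compound 2 to compound 3 (0.09 log units; within the scatter).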

Compound 3, half-maximal inhibitory concentration: 10500 nM
The estimate for compound 3 lay 1.5-fold (0.18 log units) below the measured number; low and high end bracket the measured number.
By their numbers in this assay, from the lowest: compound 1; then compounds 2 and 3 (each within the scatter of the next).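

In this assay, exchanging a six-membered carbon ring bearing two fluorines for a five-membered ring with one hetero atom, which adds a hydrogen-bond acceptor, leaves the result within the scatter at this carbonyl carbon: a 1.2-fold higher number from compound 2 to compound 3 (0.08 log units; within the scatter). The new comparison with the 3-phenylpropyl amide, a 2.8-fold higher number from compound 1 to compound 3 (0.44 log units; beyond the scatter), places compound 3 with compound 2 on the weaker side of compound 1, so among these three amides the two with an aromatic ring directly on the carbonyl carbon both read weaker than the one carrying the chain. No evidence on the origin of these differences is at hand.

From the compounds shown here alone, it remains open whether the chain itself or its length matters, and a benzyl or 2-phenylethyl group would test this. A cyclohexyl group, or an amine or carboxylic acid at the end of the chain, would also extend the comparison.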